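This account rests on a few compounds, and the source may have more. Where it says the series, first, only, none or still open, it means among the compounds named here.

In a functional assay on HT-29 cells (Homo sapiens) for antiproliferative activity, read by sulforhodamine B assay, with a stated time of 48 h (a higher number here means a weaker inhibitor, a lower number a stronger inhibitor), compound 1 `Cc1ccccc1OS(=O)(=O)c1ccc(N2CCN(C)C2=O)cc1` gives 4800 nM and compound 2 `CCc1ccccc1OS(=O)(=O)c1ccc(N2CCN(C)C2=O)cc1` gives 4600 nM, with a 1.0-fold lower number from compound 1 to compound 2 (0.02 log units; within the scatter). Compound 3 `Cc1ccc(OS(=O)(=O)c2ccc(N3CCN(C)C3=O)cc2)cc1` reads > 100000 nM, which is a limit and not a number. Compound 4 `CN1CCN(c2ccc(S(=O)(=O)Oc3ccc(F)cc3)cc2)C1=O` carries fluoro in place of methyl on an aromatic carbon, para to a large group: fluoro in place of methyl on an aromatic carbon. Among the compounds with values here, no measured step makes this exchange. The nearest are an at least 20-fold higher number from compound 1 to compound 3 (1.31 log units; beyond the scatter) and an at least 21-fold higher number from compound 2 to compound 3 (1.33 log units; beyond the scatter), both ending at the 4-methylphenyl of compound 3, and the 4-fluorophenyl of compound 4 resembles that group in name only. A small expected step follows, toward a lower number if any: an at least 1.4-fold lower number from compound 3 to compound 4 (0.15 log units; that floor lies within the scatter). The estimate for compound 4 is 70000 nM, with an expected range of 20000 nM to 100000 nM.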

Compound 4, half-maximal inhibitory concentration: > 100000 nM
Compound 4 ended at the assay's limit (the forecaster's own chance of this, stated with the estimate: 55%); middle value at least 1.4-fold (0.15 log units) away from the limit.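

In this assay compound 4 reads as a limit and not a number, as compound 3 does: the limit of > 100000 nM in this assay, at which 2 of the 4 values shown sit.

With both values at that limit, the step between compound 3 and compound 4 cannot be read, so fluoro in place of methyl remains unresolved at this place. Placing 4-fluorophenyl on the oxygen instead of 2-ethylphenyl or 2-methylphenyl gives an at least 21-fold higher number from compound 2 to compound 4 (1.33 log units; beyond the scatter) and an at least 20-fold higher number from compound 1 to compound 4 (1.31 log units; beyond the scatter), so a second group para to a large group joins 4-methylphenyl in this large loss.

From the compounds shown here alone, whether a methoxy group or an amine on this aromatic carbon would give a readable number stays open.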